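The compounds below may be only part of what the source reports. "The series", "measured", "known", "first", "only" and "open" are said of these compounds alone.

Measured compounds:
- compound 1, `CC1=C2CC(C)(C)/C=C/[C@H](O)/C(C)=C\C3=C[C@H](C)C[C@]3(O2)C1=O`: 26000 nM
- compound 2, `CC1=C2CC(C)(C)/C=C/[C@@H](O)/C(C)=C\C3=C[C@H](C)C[C@]3(O2)C1=O`: 26000 nM

In an ADME assay on Raji cells (Homo sapiens) for cytotoxicity, read by CellTiter-Glo, with a stated time of 72 h (on this read-out higher numbers stand for an effect only at larger amounts of compound and lower numbers for an effect already at smaller amounts), compound 1 gives 26000 nM. Compound 2 gives 26000 nM, so the two stand level. For the measured compounds named here, the step of no change at the digits printed from compound 1 to compound 2 (within the scatter) is the only measured comparison here, and it comes from nothing more than the fact that compounds 1 and 2 differ only in the configuration as drawn.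

Compound 3, `CC1=C2CC(C)(C)/C=C/[C@H](OC(=S)Sc3ccccc3)/C(C)=C\C3=C[C@H](C)C[C@]3(O2)C1=O`, differs from compound 1 in a different way: a group of 9 heavy atoms (7 carbon, 2 sulfur; one six-membered aromatic ring of carbon only) in place of a hydrogen atom, on an oxygen on a saturated carbon. Going by the values given here, no measured step touches a change of this kind, since the single step available swaps only the drawn configuration at one ring carbon and leaves the atoms and bonds unchanged. With nothing to lean on beyond the value of compound 1 itself, the expectation for compound 3 is a step of a 1.7-fold lower number from compound 1 to compound 3 (0.24 log units; within the scatter), close to no change, with a wide band around it. For compound 3 the estimate in this assay is therefore 15000 nM, expected to fall between 4000 nM and 50000 nM.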

Compound 3, half-maximal effective concentration: 26000 nM
The estimate for compound 3 lay 1.7-fold (0.24 log units) below the measured number; the measured number falls inside the stated range.
By their numbers in this assay, from the lowest: compounds 1, 2 and 3 (each within the scatter of the next).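

In this assay, the earlier pair changed only the drawn configuration at the carbon that carries this oxygen, whereas compound 3 changes the oxygen itself, with a group of 9 heavy atoms (7 carbon, 2 sulfur; one six-membered aromatic ring of carbon only) in place of its hydrogen, and the outcome is no change at the digits printed from compound 1 to compound 3 (within the scatter). The hydrogen on this oxygen is therefore not required to keep the number at this level, at least with this one group in its place, so the position accepts a substantial addition without a visible shift on this read-out. Nothing given here explains why the number stays put after this change.

On these data alone, whether the same holds for other groups on this oxygen remains open: a small acetyl group, a longer carbon chain, an amine or a carboxylic acid could each behave differently. As far as these compounds go, it is also open whether the group of compound 3 would give the same number on the oxygen of compound 2, where the carbon carrying it has the other drawn configuration.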